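Sulfonyl group swap from compound 2 to compound 3

A few compounds are considered here, and "the series" means these few. Any claim that something is new, unique, unknown or untested is made for them only; others in the source may bear on it.

In a functional assay on HEK293 cells (Homo sapiens) for cytotoxicity (a lower number here means that less compound is tolerated, a higher number that more compound is tolerated), compound 1 (`COc1ccc(S(=O)(=O)Nc2cccc(N3C[C@@H](c4ccc(OC)c(OC5CCCC5)c4)CC3=O)c2)cc1`) gives > 10000 nM, a limit of the assay and not a number. Compound 2 (`COc1ccc([C@H]2CC(=O)N(c3cccc(NS(=O)(=O)c4cc(C)ccc4OC)c3)C2)cc1OC1CCCC1`) gives > 10000 nM, again only a limit. Compound 3 (`COc1ccc([C@H]2CC(=O)N(c3cccc(NS(=O)(=O)c4ccccc4Cl)c3)C2)cc1OC1CCCC1`) carries 2-chlorophenyl in place of 2-methoxy-5-methylphenyl on a sulfonyl sulfur. Among the measured compounds shown here, the only measured step bearing on this place is a step that the two limits leave unreadable from compound 1 to compound 2, and it offers no size to carry over. What remains is the limit of > 10000 nM in this assay, at which 2 of the 2 values shown sit. On that basis, no change beyond the scatter is expected in this assay. The expected step is a step that the limit leaves unreadable from compound 2 to compound 3, and it rests on limits alone. For compound 3 the estimated value is 12000 nM, with an expected range of 6000 nM to 30000 nM.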

Compound 3, half-maximal cytotoxic concentration: > 10000 nM
Compound 3 gave a limit, no number; the forecaster's own chance of this, stated with the estimate: 85%; the middle value does not contradict the limit.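

In this assay no step can be read among compound 1, compound 2 and compound 3, as each gives only a limit of the assay and no number: the limit of > 10000 nM in this assay, at which 3 of the 3 values shown sit.

Going by these compounds, whether 4-methoxyphenyl, 2-methoxy-5-methylphenyl and 2-chlorophenyl on the sulfonyl sulfur differ at all in this assay stays open.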